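The source may report more compounds than this note shows. Statements on the series, on what has been measured and on what is new or still open speak of the compounds shown alone.

Three compounds share one core and differ only in the group on a saturated chain carbon bound to an amide-type nitrogen in a ring. Compound 1 `Nc1ccc(/C=C2\SC(=O)N(Cc3cccc(Cl)c3)C2=O)cc1` gives 10000 nM in a functional assay on FM3A cells (Mus musculus) for cytotoxicity, read by cell counting, with a stated time of 2 days; on this read-out lower numbers stand for stronger inhibition and higher numbers for weaker inhibition. Compound 2 `Nc1ccc(/C=C2\SC(=O)N(Cc3ccc(F)cc3)C2=O)cc1` gives 36000 nM in this assay, a change of a 3.6-fold higher number from compound 1 to compound 2 (0.56 log units; beyond the scatter). Compound 3 `Cc1ccc(CN2C(=O)S/C(=C\c3ccc(N)cc3)C2=O)cc1` shows only a limit, > 250000 nM, in this assay, so no exact number is known for it; this is the limit of > 250000 nM in this assay, at which 1 of the 3 values shown sits. The steps of an at least 25-fold higher number from compound 1 to compound 3 (1.39 log units; beyond the scatter) and an at least 6.9-fold higher number from compound 2 to compound 3 (0.84 log units; beyond the scatter) both run toward weaker inhibition. Compound 4 `CN1C(=O)S/C(=C\c2ccc(N)cc2)C1=O` differs from compound 3 by hydrogen in place of 4-methylphenyl on a saturated chain carbon bound to an amide-type nitrogen in a ring. For the measured compounds named here, no measured step removes the whole ring, so the direction is uncertain; as compound 3 already sits at the limit, compound 4 is expected to stay near it, a step that the limit leaves unreadable from compound 3 to compound 4. Compound 4 is estimated at 300000 nM, within 100000 nM to 1000000 nM.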

Compound 4, half-maximal inhibitory concentration: 107000 nM
Beside the measured number, compound 4's estimate is 2.8-fold (0.45 log units) above it; low and high end bracket the measured number.
By their numbers in this assay, from the lowest: compound 1; then compound 2; then compound 4. At a limit, above all of these: compound 3.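

Swapping the ring for hydrogen does not always weaken inhibition in this assay: the number falls in an at least 2.3-fold lower number from compound 3 to compound 4 (0.36 log units; beyond the scatter). The same swap raises the number in a 3.0-fold higher number from compound 2 to compound 4 (0.47 log units; beyond the scatter) and in an 11-fold higher number from compound 1 to compound 4 (1.03 log units; beyond the scatter), so 3-chlorophenyl and 4-fluorophenyl give stronger inhibition than hydrogen here, while 4-methylphenyl gives weaker. Compound 3 shows only a limit, so its step gives a bound and not an exact size: the limit of > 250000 nM in this assay, at which 1 of the 4 values shown sits.

The compounds shown leave open where an unsubstituted phenyl or a longer chain would fall in this place.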